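Swapping the ester aryl group on a secoiridoid glycoside

A few compounds are considered here, and "the series" means these few. Any claim that something is new, unique, unknown or untested is made for them only; others in the source may bear on it.

The shared core of compound 1 `C/C=C1/[C@H](O[C@@H]2O[C@H](CO)[C@@H](O)[C@H](O)[C@H]2O)OC=C(C(=O)OC)[C@H]1CC(=O)OCc1ccc2c(c1)OCCO2` carries a free sugar and an ester bearing a 2,3-dihydro-1,4-benzodioxin-6-yl group. In a functional assay on SK-BR-3 cells (Homo sapiens) for antiproliferative activity, read by MTT assay, with a stated time of 72 h (a lower number here means a stronger inhibitor, a higher number a weaker inhibitor), compound 1 gives > 15000 nM, which is a limit of the assay, not a number. Compound 2 `C/C=C1/[C@H](O[C@@H]2O[C@H](COC(C)=O)[C@@H](OC(C)=O)[C@H](OC(C)=O)[C@H]2OC(C)=O)OC=C(C(=O)OC)[C@H]1CC(=O)O` has an acetylated sugar and a free acid; in this assay compound 2 gives > 15000 nM, also a limit. Compound 3 `C/C=C1/[C@H](O[C@@H]2O[C@H](COC(C)=O)[C@@H](OC(C)=O)[C@H](OC(C)=O)[C@H]2OC(C)=O)OC=C(C(=O)OC)[C@H]1CC(=O)OCCC`, its propyl ester, gives 6600 nM. For the measured compounds named here, the only step measured, an at least 2.2-fold lower number from compound 2 to compound 3 (0.35 log units; beyond the scatter), changes the ester, not the sugar. Compound 4 `C/C=C1/[C@H](O[C@@H]2O[C@H](CO)[C@@H](O)[C@H](O)[C@H]2O)OC=C(C(=O)OC)[C@H]1CC(=O)OCCc1ccc(O)cc1` differs from compound 1 by 4-hydroxybenzyl in place of 2,3-dihydro-1,4-benzodioxin-6-yl on a saturated chain carbon bound to an oxygen next to a carbonyl group. Going by the values given here, no measured step covers this change, and compound 1 sits at the limit of > 15000 nM in this assay, at which 2 of the 3 values shown sit. Compound 4 is therefore expected to stay weak, with an estimated step of a number no higher from compound 1 to compound 4 (the limit leaves the size open) and a value near 15000 nM, ranging from 5000 nM to 40000 nM.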

Compound 4, half-maximal inhibitory concentration: > 20000 nM
Compound 4: no number, only a limit (the forecaster's own chance of this, stated with the estimate: 60%); middle value at least 1.3-fold (0.12 log units) away from the limit.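

In this assay, for the compounds shown here, compound 4 gives > 20000 nM, a limit of the assay and not a number; compound 1 also rests on a limit, so no step between compound 1 and compound 4 can be read. Going by these compounds, how strongly either compound acts, and whether 4-hydroxybenzyl differs from 2,3-dihydro-1,4-benzodioxin-6-yl here, stays open.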